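Cinnamamide series: methoxy for trifluoromethyl on the aryl

The compounds below may be only part of what the source reports. "The series", "measured", "known", "first", "only" and "open" are said of these compounds alone.

Measured compounds:
- compound 1 `CN(C)CCC(NC(=O)/C=C/c1ccc(C(F)(F)F)cc1)c1ccc2ccccc2c1`: 135 nM
- compound 2 `CN(C)CCC(NC(=O)CCc1ccc(C(F)(F)F)cc1)c1ccc(Cl)cc1`: 1120 nM

Both numbers come from a functional assay on NIH3T3 cells for agonist activity at Urotensin-2 receptor (Homo sapiens), with a stated time of 5 days; a higher number here means that more compound is needed for the effect, a lower number that less compound is needed. Compound 1 holds the lowest number of the two; compound 2 lies above it by a gap beyond the usual scatter. Among the measured compounds shown here, compound 2 differs from compound 1 in more than one place, so no single-change step between measured compounds is available.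

Compound 3 `COc1ccc(/C=C/C(=O)NC(CCN(C)C)c2ccc3ccccc3c2)cc1` keeps the core of compound 1 and differs from it only by methoxy in place of trifluoromethyl on an aromatic carbon. For the measured compounds named here, with no measured pair isolating this change, the direction rests on compound 1 alone, and a moderate rise in the number, of a size near the edge of the scatter, is expected rather than a drop. Compound 3 is expected to give about 400 nM in this assay, within a range of 100 nM to 1500 nM. The expected step is a 3.0-fold higher number from compound 1 to compound 3 (0.47 log units; beyond the scatter).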

Compound 3, half-maximal effective concentration: 380 nM
Compound 3: middle estimate off by 1.1-fold (0.02 log units), on the high side; the measured number falls inside the stated range.
By their numbers in this assay, from the lowest: compound 1; then compound 3; then compound 2.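

In this assay the position on the aromatic carbon para to a large group now has its first single-change step, and moving from 4-(trifluoromethyl)phenyl to 4-methoxyphenyl gives (a 2.8-fold higher number from compound 1 to compound 3 (0.45 log units; beyond the scatter)), modest but beyond the scatter. The number at this position therefore depends on the group it carries, yet agonist activity survives an exchange that brings in one hydrogen-bond acceptor where trifluoromethyl counts none. No measurement here explains the direction or size of this step.

Going by these compounds, with only these two groups compared at this position, it remains open how a nitrile, a chlorine, a hydroxyl or an unsubstituted carbon would rank against them. On these data alone, it is also open whether the same exchange gives a similar step on the core of compound 2, which differs from compound 1 in more than one place.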